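This account rests on a few compounds, and the source may have more. Where it says the series, first, only, none or still open, it means among the compounds named here.

Measured so far in an ADME assay on MT4 cells (Homo sapiens) for cytotoxicity, read by MTT assay, with a stated time of 4 days; on this read-out higher numbers stand for lower toxicity in this test and lower numbers for higher toxicity in this test:
compound 1 `CSc1ccc(/C=N/NC(=O)COc2cccc3ccccc23)cc1` gives 68.3 ug/mL
compound 3 `O=C(COc1cccc2ccccc12)N/N=C/c1ccc(F)cc1` gives 65.1 ug/mL
compound 2 `O=C(COc1cccc2ccccc12)N/N=C/c1ccccc1` gives >= 96.6 ug/mL, which is a limit of this assay and not a number.

Compound 3 holds the lowest of the two numbers shown in this assay, with compound 1 nearest: the gap a 1.0-fold lower number from compound 1 to compound 3 (0.02 log units; within the scatter) lies within the scatter, so no order between the two can be read. Compound 2 sits at the limit of >= 96.6 ug/mL in this assay, at which 1 of the 3 values shown sits. The other steps across the series, an at least 1.4-fold higher number from compound 1 to compound 2 (0.15 log units; that floor lies within the scatter) and an at least 1.4-fold lower number from compound 2 to compound 3 (0.17 log units; that floor lies within the scatter), rest on that limit and their floors also fall within the scatter. All three measured steps exchange one small group on the same aromatic ring, and none of them produced a change in this assay that can be told from repeat noise.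

Compound 4 `O=C(COc1cccc2ccccc12)N/N=C/c1cccc(Cl)c1` differs from compound 3 by 3-chlorophenyl in place of 4-fluorophenyl on a carbon with a double bond to nitrogen. This is again a change of a small substituent on that ring, of the same kind as the steps already measured, so no step beyond the scatter is expected in this assay for compound 4, in either direction. The step from compound 3 is expected to be a 1.1-fold lower number from compound 3 to compound 4 (0.04 log units; within the scatter). The value expected for compound 4 is 60 ug/mL, with a range from 30 ug/mL to 110 ug/mL.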

Compound 4, half-maximal cytotoxic concentration: 89.9 ug/mL
Compound 4: the middle estimate sits 1.5-fold (0.18 log units) below what was measured; measured number inside the range.
By their numbers in this assay, from the lowest: compounds 3, 1 and 4 (each within the scatter of the next). At a limit, above all of these: compound 2.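

In this assay, 3-chlorophenyl in place of 4-fluorophenyl on a carbon with a double bond to nitrogen gives a 1.4-fold higher number from compound 3 to compound 4 (0.14 log units; within the scatter), no change that can be told from repeat noise, even though the halogen and its ring position both differ. The same holds against the 4-(methylsulfanyl)phenyl compound, with a 1.3-fold higher number from compound 1 to compound 4 (0.12 log units; within the scatter), so compounds 1, 3 and 4 cannot be ordered in this assay, and the earlier finding now extends to a substituent at a different ring position from those in compound 1 and compound 3. Compound 2 holds a limit of the assay and not a number: the limit of >= 96.6 ug/mL in this assay, at which 1 of the 4 values shown sits. The step that rests on this limit is an at least 1.0-fold lower number from compound 2 to compound 4 (0.03 log units; that floor lies within the scatter), and no order can be read from it.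

Because the halogen and its ring position change together in the step from compound 3, the compounds shown cannot separate the contribution of either, and a 4-chlorophenyl or 3-fluorophenyl analogue would be needed to do so. On these data alone, it also stays open whether a group of another kind on this ring, such as an amine or a carboxylic acid, would give a step beyond the scatter.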